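A few compounds are considered here, and "the series" means these few. Any claim that something is new, unique, unknown or untested is made for them only; others in the source may bear on it.

In a physicochemical assay, with a stated time of 6 min (a lower number here means a stronger inhibitor, a higher number a weaker inhibitor), compound 3 `O=C(Nc1cccc(Cl)c1)Nc1nc(-c2cc3ccccc3o2)cs1` gives 14100 nM, the lowest number in the series, while compound 1 `O=C(Nc1ccc(I)cc1)Nc1nc(-c2cc3ccccc3o2)cs1` gives 62000 nM. Compound 2 `Cc1ccc(NC(=O)Nc2nc(-c3cc4cc(Br)ccc4o3)cs2)cc1` is reported only as a limit, > 200000 nM. Compound 4 `Cc1ccc(NC(=O)Nc2nc(-c3cc4ccccc4o3)cs2)cc1` differs from compound 3 by 4-methylphenyl in place of 3-chlorophenyl on an amide-type nitrogen, with 4-methylphenyl in place of 3-chlorophenyl on an amide-type nitrogen. Among the measured compounds shown here, only one measured step bears on this place: a 4.4-fold lower number from compound 1 to compound 3 (0.64 log units; beyond the scatter), modest but beyond the scatter. Leaving 3-chlorophenyl there cost a step of that size in the reverse direction, so a higher number of similar size is expected on losing it again, on the assumption that 4-methylphenyl behaves like 4-iodophenyl. The expected step is a 3.2-fold higher number from compound 3 to compound 4 (0.50 log units; beyond the scatter). For compound 4 the estimate is 45000 nM, with an expected range of 14000 nM to 170000 nM.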

Compound 4, half-maximal inhibitory concentration: 500 nM
Beside the measured number, compound 4's estimate is 90-fold (1.95 log units) above it; the measured number lies below the stated range.
By their numbers in this assay, from the lowest: compound 4; then compound 3; then compound 1. At a limit, above all of these: compound 2.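

Among the compounds shown here, at this amide-type nitrogen, the group matters far more than the earlier compounds showed: 4-methylphenyl in place of 3-chlorophenyl gives a 28-fold lower number from compound 3 to compound 4 (1.45 log units; beyond the scatter), and methyl in place of iodo on an aromatic carbon gives a 120-fold lower number from compound 1 to compound 4 (2.09 log units; beyond the scatter). 4-Methylphenyl alone does not secure a low number, since hydrogen in place of bromo on an aromatic carbon gives an at least 400-fold lower number from compound 2 to compound 4 (2.60 log units; beyond the scatter). Compound 2 stands only as a limit, not a number: the limit of > 200000 nM in this assay, at which 1 of the 4 values shown sits.

Open, from the compounds shown here alone, is whether the methyl itself or its place on the ring carries the step. A 3-methylphenyl or a 4-chlorophenyl group would separate the two.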